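A few compounds are considered here, and "the series" means these few. Any claim that something is new, unique, unknown or untested is made for them only; others in the source may bear on it.

Compound 3, `Cc1c(Cc2ccc(-c3ccc(C(F)(F)F)cc3)cc2)c(=O)oc2cc(OCC(O)CN3CCC(C(N)=O)CC3)ccc12`, is the starting point here. In an ADME assay on A549 cells (Homo sapiens) for cytotoxicity, read by CellTiter-Glo (a higher number here means that more compound is tolerated, a lower number that less compound is tolerated), compound 3 gives > 100000 nM, which is a limit of the assay rather than a number. Compound 1, `COC(=O)c1ccc(Cc2c(C)c3ccc(OCC(O)CN4CCC(C(N)=O)CC4)cc3oc2=O)cc1`, gives > 100000 nM in this assay, again a limit. Compound 2, `Cc1noc(C)c1-c1ccc(Cc2c(C)c3ccc(OCC(O)CN4CCC(C(N)=O)CC4)cc3oc2=O)cc1`, is the only one of the three with a measured number, giving 36900 nM in this assay. So two of the three values sit at the same limit, as the limit of > 100000 nM in this assay, at which 2 of the 3 values shown sit, records, and compound 3 cannot be placed above or below compound 1; it can only be said to sit at that limit.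

Compound 4 is `Cc1c(Cc2ccc(-c3ccc(C#N)c(F)c3)cc2)c(=O)oc2cc(OCC(O)CN3CCC(C(N)=O)CC3)ccc12`. The change from compound 3 is 4-cyano-3-fluorophenyl in place of 4-(trifluoromethyl)phenyl on an aromatic carbon. Going by the values given here, none of the measured steps exchanges one aryl group for another, so they bear on the new compound only indirectly: an at least 2.7-fold higher number from compound 2 to compound 3 (0.43 log units; beyond the scatter) and an at least 2.7-fold lower number from compound 1 to compound 2 (0.43 log units; beyond the scatter) show that the oxazole is the one group that pulls the number down, while a step that the two limits leave unreadable from compound 1 to compound 3 is unreadable. Compound 4 keeps an aryl group, so the expected step of an at least 1.2-fold lower number from compound 3 to compound 4 (0.09 log units; that floor lies within the scatter) is none beyond the scatter, though the limit may hide it. Compound 4 is therefore estimated at 80000 nM, between 30000 nM and 150000 nM.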

Compound 4, half-maximal cytotoxic concentration: 29100 nM
Compound 4: the middle estimate sits 2.7-fold (0.44 log units) above what was measured, and the stated range ends above it.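

Going by these compounds alone, the earlier compounds left the oxazole as the only group that lowered the number, but in this assay a substituted phenyl ring on this aromatic carbon lowers it too, with an at least 3.4-fold lower number from compound 3 to compound 4 (0.53 log units; beyond the scatter). The exchange for methoxycarbonyl reads the same way, with an at least 3.4-fold lower number from compound 1 to compound 4 (0.53 log units; beyond the scatter), whereas the exchange for the oxazole gives a 1.3-fold lower number from compound 2 to compound 4 (0.10 log units; within the scatter), so those two compounds cannot be told apart. Keeping a phenyl ring at this place is therefore not enough to keep the number at the limit; what the ring carries matters.

As far as these compounds go, the step between compounds 1 and 3 cannot be read, and the true size of the steps from them stays open because both sit at a limit: the limit of > 100000 nM in this assay, at which 2 of the 4 values shown sit. From the compounds shown here alone, whether the nitrile or the fluorine goes with the drop is also open, as is how a phenyl ring carrying only a nitrile, or an amine, would behave.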